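Five-membered ring swap at the aryl terminus of compound 1

A few compounds are considered here, and "the series" means these few. Any claim that something is new, unique, unknown or untested is made for them only; others in the source may bear on it.

Within the data shown here, compound 1 `CCC(C)(C)Cc1c[nH]c(CCc2ccc(-n3cccn3)cc2)n1` gives 135 nM in a functional assay on HEK293 cells for agonist activity at Bombesin receptor subtype-3 (Homo sapiens), read by luminescence and calcium flux, with a stated time of 10 min (on this read-out lower numbers stand for an effect already at smaller amounts and higher numbers for an effect only at larger amounts of compound), and stands second highest of the three numbers measured so far. Compound 2 `CCC(C)(C)Cc1c[nH]c(CCc2ccc(-c3ccc(F)cn3)cc2)n1` gives 66 nM, and the step of a 2.0-fold lower number from compound 1 to compound 2 (0.31 log units; beyond the scatter) is modest. Compound 3 `CCC(C)(C)Cc1c[nH]c(CCc2ccc(-c3csnn3)cc2)n1` gives 538 nM; the step of a 4.0-fold higher number from compound 1 to compound 3 (0.60 log units; beyond the scatter) and the step of an 8.2-fold higher number from compound 2 to compound 3 (0.91 log units; beyond the scatter) both point the same way.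

Compound 4 `CCC(C)(C)Cc1c[nH]c(CCc2ccc(-c3cnsc3)cc2)n1` has not been measured. It differs from compound 1 in one place: 1,2-thiazol-4-yl in place of 1H-pyrazol-1-yl on an aromatic carbon on an aromatic carbon of a six-membered aromatic ring of carbon only, para to a large group. Among the measured compounds shown here, the step that bears most directly on it is the move to another sulfur-containing five-membered ring, a 4.0-fold higher number from compound 1 to compound 3 (0.60 log units; beyond the scatter), which gave a higher number; no measured pair shows the 1,2-thiazol-4-yl group itself. A higher number than compound 1 is therefore expected, though smaller than that step, since 1,2-thiazol-4-yl keeps one nitrogen and one sulfur rather than two nitrogens and a sulfur. Compound 4 is estimated at 250 nM, with a range of 100 nM to 650 nM, which means an expected step of a 1.9-fold higher number from compound 1 to compound 4 (0.27 log units; within the scatter).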

Compound 4, half-maximal effective concentration: 44 nM
Beside the measured number, compound 4's estimate is 5.7-fold (0.75 log units) above it; the whole stated range lies above it.
By their numbers in this assay, from the lowest: compounds 4 and 2 (each within the scatter of the next); then compound 1; then compound 3.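

On an aromatic carbon of the six-membered aromatic ring, para to a large group, a sulfur-containing five-membered ring is not in itself a disadvantage in this assay: the two such rings are far apart, with a 12-fold lower number from compound 3 to compound 4 (1.09 log units; beyond the scatter), and 1,2-thiazol-4-yl also improves on 1H-pyrazol-1-yl, with a 3.1-fold lower number from compound 1 to compound 4 (0.49 log units; beyond the scatter). A five-membered ring thus reaches the level of the 5-fluoropyridin-2-yl group, since a 1.5-fold lower number from compound 2 to compound 4 (0.18 log units; within the scatter) leaves the two compounds indistinguishable. Nothing available explains why rings of the same size read so differently here.

Still open, as far as these compounds go, is how a methyl group or an aminomethyl group on the 1,2-thiazol-4-yl ring would read in this assay. Also open is whether the order among these rings would hold with a shorter chain on the shared core.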